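Oxolan-2-yl to Cyclobutyl on the Carbonyl of Compound 3

This account rests on a few compounds, and the source may have more. Where it says the series, first, only, none or still open, it means among the compounds named here.

Compound 1 `O=C(N1CCC(F)CC1)N1CC(c2nc(-c3cccc(Cl)c3)no2)C1`: in an assay on HEK293 cells for negative allosteric modulation of metabotropic glutamate receptor 5 (Homo sapiens), read by FLIPR (on this read-out lower numbers stand for stronger inhibition and higher numbers for weaker inhibition), compound 1 gives > 10000 nM, which is a limit of the assay.
Compound 2 `O=C(N1CCCCC1)N1CC(c2nc(-c3cccc(Cl)c3)no2)C1`: in this assay compound 2 gives > 10000 nM, again a limit.
Compound 3 `O=C(C1CCCO1)N1CC(c2nc(-c3cccc(Cl)c3)no2)C1`: in this assay compound 3 gives 890 nM.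

Among the measured compounds shown here, compound 3 therefore holds the only number among the three; the other two sit at the limit of > 10000 nM in this assay, at which 2 of the 3 values shown sit. The step from compound 1 to compound 2 is unreadable, since a step that the two limits leave unreadable from compound 1 to compound 2. The two steps that reach compound 3 are both large: an at least 11-fold lower number from compound 1 to compound 3 (1.05 log units; beyond the scatter) and an at least 11-fold lower number from compound 2 to compound 3 (1.05 log units; beyond the scatter), each a change at the carbonyl carbon.

Compound 4 `O=C(C1CCC1)N1CC(c2nc(-c3cccc(Cl)c3)no2)C1` differs from compound 3 at that same carbonyl carbon: cyclobutyl in place of oxolan-2-yl on a carbonyl carbon. Both measured steps at this position were large, but they replaced a nitrogen-linked ring with a carbon-linked one, whereas compound 4 keeps a carbon-linked ring and only exchanges oxolan-2-yl for cyclobutyl. For the measured compounds named here, no measured pair shows that exchange. The expectation is a step of a 1.5-fold higher number from compound 3 to compound 4 (0.16 log units; within the scatter), within the scatter or a little toward higher numbers. Compound 4 is estimated at 1300 nM, between 400 nM and 4500 nM.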

Compound 4, half-maximal inhibitory concentration: 1500 nM
Estimate against measurement, compound 4: 1.2-fold (0.06 log units) below; low and high end bracket the measured number.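

With a 1.7-fold higher number from compound 3 to compound 4 (0.23 log units; within the scatter), oxolan-2-yl and cyclobutyl on the carbonyl carbon cannot be told apart in this assay, so a number in this range at this position does not depend on the ring oxygen or on the one hydrogen-bond acceptor that leaves with it. The gap to the nitrogen-linked rings also holds for a carbon-linked ring of carbon only, as an at least 6.6-fold lower number from compound 2 to compound 4 (0.82 log units; beyond the scatter) and an at least 6.6-fold lower number from compound 1 to compound 4 (0.82 log units; beyond the scatter) show, and among the four compounds neither carbon-linked ring goes against this. Both of those sizes are only minimums, as each starts from a compound that sits at a limit of the assay: the limit of > 10000 nM in this assay, at which 2 of the 4 values shown sit.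

The compounds shown leave open whether the gap follows the nitrogen link on the carbonyl or the piperidine ring itself, a question that a smaller nitrogen-linked ring such as azetidin-1-yl or pyrrolidin-1-yl would address. Also open, on these data alone, is how an open chain such as isopropyl, or a carbon-linked ring carrying an amine, would compare with oxolan-2-yl and cyclobutyl on the same carbonyl.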